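The source may report more compounds than this note shows. Statements on the series, on what has been measured and on what is new or still open speak of the compounds shown alone.

Series notes. The reference point is compound 1 `CC(C)(C)c1ccc(CNC(=O)NCc2ccc(NS(C)(=O)=O)c(F)c2)cc1`; in a functional assay (strain Sprague-Dawley) for antagonist activity at transient receptor potential cation channel subfamily V member 1 (Rattus norvegicus) (on this read-out higher numbers stand for weaker inhibition and lower numbers for stronger inhibition), compound 1 gives 710 nM. Compound 2 `CS(=O)(=O)Nc1ccc(CNC(=O)CCc2ccc(Br)cc2)cc1F` carries the same sulfonamide-bearing core on a propanamide linker, with a bromo substituent on the far ring. In this assay compound 2 gives > 10000 nM, which is a limit of the assay and not a number (the limit of > 10000 nM in this assay, at which 1 of the 2 values shown sits). Within the data shown here, no step between measured compounds can be counted here: the two values show only that compound 1 has a number and compound 2 has a limit.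

Compound 3 `CS(=O)(=O)Nc1ccc(CNC(=O)CCc2ccc(CC3CC3)cc2)cc1F` is the next entry. Relative to compound 2 the change is cyclopropylmethyl in place of bromo on an aromatic carbon. Among the measured compounds shown here, no measured pair covers this change, so the expectation rests on compound 2 alone and is wide. The step from compound 2 to compound 3 is expected to be an at least 3.3-fold lower number from compound 2 to compound 3 (0.52 log units; beyond the scatter), toward stronger inhibition and beyond the scatter, although a limit again remains a fair possibility. Compound 3 is estimated at 3000 nM, with a range from 600 nM to 15000 nM.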

Compound 3, half-maximal inhibitory concentration: 360 nM
Compound 3: the middle estimate sits 8.3-fold (0.92 log units) above what was measured; measured number outside the range, below it.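

On the far ring, at the aromatic carbon para to a large group, the propanamide compounds now have a number: in this assay compound 3 gives 360 nM. Compound 2 stays a limit of the assay and not a number: the limit of > 10000 nM in this assay, at which 1 of the 3 values shown sits. Cyclopropylmethyl in place of bromo gives an at least 27-fold lower number from compound 2 to compound 3 (1.44 log units; beyond the scatter), so this position is not indifferent to its substituent on this linker, and the size of the step is a minimum and not a measured difference.

This single pair cannot say whether the step belongs to the three-membered ring or simply to the larger all-carbon group, a question that an open butyl chain at the same place would help to separate. Also open, on these data alone, is how an amine or a carboxylic acid would read at this position, and whether cyclopropylmethyl on the far ring would carry over to the urea linker of compound 1.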